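Removing the Nitro Group from Compound 1

The compounds below may be only part of what the source reports. "The series", "measured", "known", "first", "only" and "open" are said of these compounds alone.

Compound 1 `Cn1c(=O)c(S(=O)(=O)c2ccc(F)cc2[N+](=O)[O-])cc2cnc(Nc3ccc4[nH]ccc4c3)nc21`: 1500 nM
Compound 2 `Cn1c(=O)c(S(=O)(=O)c2ccc(F)cc2F)cc2cnc(Nc3ccc4[nH]ncc4c3)nc21`: 30000 nM
Compound 3 `Cn1c(=O)c(S(=O)(=O)c2ccc(F)cc2F)cc2cnc(Nc3ccc4cccc(O)c4n3)nc21`: 5000 nM

All three values come from a functional assay on DU-145 cells (Homo sapiens) for inhibition, read by trypan blue exclusion, with a stated time of 72 h; a higher number here means a weaker inhibitor, a lower number a stronger inhibitor. Compound 1 gives the lowest number of the three; compound 3 stands nearest to it and compound 2 furthest. Going by the values given here, the only step between compounds differing in one place, a 6.0-fold lower number from compound 2 to compound 3 (0.78 log units; beyond the scatter), swaps the group on the aromatic amine nitrogen and leaves untouched the part of the molecule that changes here. Compound 4 `Cn1c(=O)c(S(=O)(=O)c2ccc(F)cc2)cc2cnc(Nc3ccc4[nH]ccc4c3)nc21` differs from compound 1 as follows: hydrogen in place of nitro on an aromatic carbon. Cut one bond further out, the change reads 4-fluoro-2-nitrophenyl to 4-fluorophenyl. Among the compounds with values here, no measured pair shows what this removal does, so the expectation is uncertain: a step of at most modest size, leaning toward a weaker inhibitor, is expected, namely a 2.0-fold higher number from compound 1 to compound 4 (0.30 log units; within the scatter). Compound 4 is therefore estimated at 3000 nM, with a range from 800 nM to 12000 nM.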

Compound 4, half-maximal inhibitory concentration: 300 nM
Compound 4: middle estimate off by 10-fold (1.00 log units), on the high side, and the stated range ends above it.
By their numbers in this assay, from the lowest: compound 4; then compound 1; then compound 3; then compound 2.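

In this assay the nitro group of the 4-fluoro-2-nitrophenyl ring proves unnecessary: its removal gives a 5.0-fold lower number from compound 1 to compound 4 (0.70 log units; beyond the scatter) and yields a stronger inhibitor. Going by these compounds alone, the earlier compounds included no pair that changed this position, so this is the first direct sign that hydrogen serves better here than nitro. Nothing available explains why the number falls. Still open, from the compounds shown here alone, is how other groups at this place would behave, such as an amine, a methoxy group or a chlorine atom, and whether the same gain holds with a different group on the aromatic amine nitrogen.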